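Replacing the methoxyphenyl group with a methylphenyl group

This account rests on a few compounds, and the source may have more. Where it says the series, first, only, none or still open, it means among the compounds named here.

Of the compounds shown here, two built on a shared core have been measured in an assay on isolated protein for displacement of a labelled ligand from D(4) dopamine receptor (Homo sapiens); on this read-out lower numbers stand for stronger inhibition and higher numbers for weaker inhibition. Compound 1 `O=C(NC1CCN(Cc2ccc(Cl)cc2)CC1)c1cccc2ccccc12` gives 43 nM in this assay. For the measured compounds named here, compound 2 `COc1ccc(CN2CCC(NC(=O)c3cccc4ccccc34)CC2)cc1` gives 223 nM in this assay, the higher of the two numbers, and the only measured step, a 5.2-fold higher number from compound 1 to compound 2 (0.71 log units; beyond the scatter), separates it from compound 1. Compound 3 `Cc1ccccc1CN1CCC(NC(=O)c2cccc3ccccc23)CC1` has not been measured; it differs from compound 2 by 2-methylphenyl in place of 4-methoxyphenyl on a saturated chain carbon bound to an amine nitrogen in a ring. Going by the values given here, no measured step tells what a methyl group does in place of a methoxy group on that ring. Among the compounds with values here, the one available step shows that a change of the group on this ring moves the number beyond the scatter, so a change of similar size in either direction would not surprise. With no direction indicated, the number for compound 3 is expected to sit between the two measured values, giving an expected step of a 2.2-fold lower number from compound 2 to compound 3 (0.35 log units; beyond the scatter). Compound 3 is therefore estimated at 100 nM in this assay, within a range of 30 nM to 350 nM.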

Compound 3, inhibition constant: 155 nM
Beside the measured number, compound 3's estimate is 1.6-fold (0.19 log units) below it; the range from low to high includes it.
By their numbers in this assay, from the lowest: compound 1; then compounds 3 and 2 (each within the scatter of the next).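

In this assay, the 2-methylphenyl group of compound 3 and the 4-methoxyphenyl group of compound 2 cannot be told apart, with a 1.4-fold lower number from compound 2 to compound 3 (0.16 log units; within the scatter). Against the 4-chlorophenyl group, the 2-methylphenyl group gives a 3.6-fold higher number from compound 1 to compound 3 (0.56 log units; beyond the scatter), so compound 1 now holds the lowest number of the three, with steps beyond the scatter to both others, and two different groups at this place both stand away from it. Nothing at hand bears on why the 4-chlorophenyl group stands apart.

The compounds shown leave open what 4-methylphenyl or 2-chlorophenyl would give at this place, so the step to compound 3 cannot be divided between the change of group and the change of its place on the ring. They also leave open whether 4-fluorophenyl or 4-bromophenyl would stay close to compound 1.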